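Replacing an Ethynyl Group with a Cyanophenyl Ring

The source may hold more compounds than are shown below. What is called first, only, known or untested is meant among the compounds shown, and "the series" means these compounds.

Compound 1 `C#Cc1cccc(NC(=O)CCc2cccc3c2B(O)OC3)c1` was examined in a functional assay on HCT-116 cells (Homo sapiens) for antiproliferative activity, read by MTT assay, with a stated time of 72 h (on this read-out lower numbers stand for stronger inhibition and higher numbers for weaker inhibition), where compound 1 gives 3600 nM, the highest of the two numbers recorded. The nearest number belongs to compound 2 `C#Cc1ccccc1NC(=O)CCc1cccc2c1B(O)OC2`, which in this assay gives 1400 nM, a difference beyond the usual scatter. Compound 3 `N#Cc1ccc(-c2cccc(NC(=O)CCc3cccc4c3B(O)OC4)c2)cc1` differs from compound 1 by 4-cyanophenyl in place of ethynyl on an aromatic carbon. Among the compounds with values here, no measured pair shows this change, so its effect is uncertain; a step of modest size toward a lower number, or none beyond the scatter, seems most plausible. Compound 3 is expected to give about 2500 nM, in the range 800 nM to 8000 nM, with the estimated step of a 1.4-fold lower number from compound 1 to compound 3 (0.16 log units; within the scatter).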

Compound 3, half-maximal inhibitory concentration: 410 nM
The estimate for compound 3 lay 6.1-fold (0.79 log units) above the measured number; the whole stated range lies above it.
By their numbers in this assay, from the lowest: compound 3; then compound 2; then compound 1.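

In this assay, swapping ethynyl for the much larger 4-cyanophenyl on this aromatic carbon gives an 8.8-fold lower number from compound 1 to compound 3 (0.94 log units; beyond the scatter), so this position tolerates an added aromatic ring and activity improves rather than being lost. Nothing available explains why the step arises. As far as these compounds go, it remains open whether the ring alone or its nitrile accounts for the step, which a plain phenyl group could separate. Also open, from the compounds shown here alone, is whether an amine or a carboxylic acid in place of the nitrile would keep the lower number.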